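Cytotoxicity of a fourth amide analogue on colon cells

The source may hold more compounds than are shown below. What is called first, only, known or untested is meant among the compounds shown, and "the series" means these compounds.

Compound 1 (`Cc1ccc(NC(=O)c2cccc(/C=C3\CC(=O)N(c4ccccc4)C3=O)c2)cc1C`) was tested in an ADME assay on NCM460 cells (Homo sapiens) for cytotoxicity, read by MTT assay, with a stated time of 72 h; a lower number here means a stronger inhibitor, a higher number a weaker inhibitor. In this assay compound 1 gives > 100000 nM, which is a limit of the assay rather than a measured number. Two relatives share its core. Compound 2 (`COc1ccc(NC(=O)c2cccc(/C=C3\CC(=O)N(c4ccc(C)cc4)C3=O)c2)cc1`) gives > 100000 nM, again a limit of the assay. Compound 3 (`CCc1cccc(NC(=O)c2cccc(/C=C3\CC(=O)N(c4ccc(C)cc4)C3=O)c2)c1`) gives > 100000 nM, also a limit of the assay. Because of the limit of > 100000 nM in this assay, at which 3 of the 3 values shown sit, compound 1 cannot be placed above or below its two relatives; all three stand at the same edge of what the assay can report. Among the compounds with values here, the only measured step, a step that the two limits leave unreadable from compound 2 to compound 3, is therefore unreadable in size and direction.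

Compound 4 (`O=C(Nc1ccc(Cl)cc1)c1cccc(/C=C2\CC(=O)N(c3ccccc3)C2=O)c1`) is the next compound to be measured. It differs from compound 1 in one place: 4-chlorophenyl in place of 3,4-dimethylphenyl on an amide-type nitrogen. Within the data shown here, no measured step bears on this change, and the one step that exists tells nothing about size. The expectation is therefore that compound 4 behaves like compound 1 and the step of a number no higher from compound 1 to compound 4 (the limit leaves the size open) is estimated to stay within the scatter. Compound 4 is expected to give about 100000 nM, most likely again as a limit, within a range from 50000 nM to 200000 nM.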

Compound 4, half-maximal inhibitory concentration: > 100000 nM
Compound 4 gave a limit, no number; the forecaster's own chance of this, stated with the estimate: 80%; the middle value lies on the limit itself.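

In this assay compound 4 gives > 100000 nM, a limit of the assay and not a number, so the step from compound 1 to compound 4 cannot be read in size or direction, because all the values stand at one edge: the limit of > 100000 nM in this assay, at which 4 of the 4 values shown sit.

The compounds shown leave open how far each lies beyond that limit, and whether any group on the amide nitrogen of this shared core would give a measurable value.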